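Tolerance of Three Amides, and a Fourth Awaited

A few compounds are considered here, and "the series" means these few. Any claim that something is new, unique, unknown or untested is made for them only; others in the source may bear on it.

Compound 1 `Cn1c(-c2ccc(C#N)cc2)cnc1NC(=O)c1ncc[nH]1`: > 100000 nM (a limit)
Compound 2 `CCCCn1c(-c2ccc(OC)cc2)cnc1NC(=O)c1ccc(F)cc1`: > 100000 nM (a limit)
Compound 3 `COc1ccc(-c2cnc(NC(=O)C3CCCC3)n2C)cc1`: > 100000 nM (a limit)

In a toxicity assay on THP-1 cells (Homo sapiens) for inhibition (a lower number here means that less compound is tolerated, a higher number that more compound is tolerated), compound 1 gives > 100000 nM, which is a limit of the assay and not a number. Compound 2 gives > 100000 nM in this assay, again a limit. Compound 3 gives > 100000 nM in this assay, also a limit. Compound 3 therefore stands where the other two stand: at the limit of > 100000 nM in this assay, at which 3 of the 3 values shown sit. Among the compounds with values here, no two of the measured compounds differ in a single place, so no measured step exists from which a size of change could be read.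

Compound 4 `COc1ccc(-c2cnc(NC(=O)c3ccc(Cl)cc3)n2C)cc1` is not yet measured. It differs from compound 3 by 4-chlorophenyl in place of cyclopentyl on a carbonyl carbon. With every measured value at the same limit, the author expects no step beyond the usual scatter in this assay, and the estimated step of a number no higher from compound 3 to compound 4 (the limit leaves the size open) is meant as essentially none. Compound 4 is thus expected at about 100000 nM, within a range from 40000 nM to 300000 nM, and most probably the assay will again report only a limit.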

Compound 4, half-maximal cytotoxic concentration: > 100000 nM
Compound 4 ended at the assay's limit; the forecaster's own chance of this, stated with the estimate: 80%; the middle value sits exactly at the limit.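

In this assay compound 3 and compound 4 both stand at a limit and not a number, so no step between them can be read: the limit of > 100000 nM in this assay, at which 4 of the 4 values shown sit.

The compounds shown leave open at what concentration any of them stops being tolerated, and whether 4-chlorophenyl in place of cyclopentyl changes that concentration at all.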